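The source may hold more compounds than are shown below. What is called first, only, known or untested is meant among the compounds shown, and "the series" means these compounds.

In a functional assay on HeLa cells (Homo sapiens) for inhibition, read by MTT assay, with a stated time of 72 h (a lower number here means a stronger inhibitor, a higher number a weaker inhibitor), compound 1 `CC(C)C[C@H](NC(=O)CCC[C@H](NC(=O)OC(C)(C)C)C(=O)NCc1ccc2ccccc2c1)B(O)O` gives > 10000 nM, which is a limit and not a number. Compound 2 `CC(C)C[C@H](NC(=O)CC[C@H](NC(=O)OC(C)(C)C)C(=O)NCc1ccc2ccccc2c1)B(O)O` gives > 10000 nM, also a limit. Among the compounds with values here, the evidence therefore amounts to the limit of > 10000 nM in this assay, at which 2 of the 2 values shown sit, and the one measured step, a step that the two limits leave unreadable from compound 1 to compound 2, has no readable size. Compound 3 `CC(C)C[C@H](NC(=O)CCC[C@H](NC(=O)CNC(=O)OC(C)(C)C)C(=O)NCc1ccc2ccccc2c1)B(O)O` carries ((tert-butoxycarbonyl)amino)methyl in place of tert-butoxy on a carbonyl carbon. Within the data shown here, no measured step sets a size or direction for this change in this assay, so none beyond the scatter is expected. The expected step is a step that the limit leaves unreadable from compound 1 to compound 3. Compound 3 is estimated at 12000 nM, with an expected range of 4000 nM to 30000 nM.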

Compound 3, half-maximal inhibitory concentration: > 10000 nM
Compound 3: no number, only a limit (the forecaster's own chance of this, stated with the estimate: 75%); the middle value does not contradict the limit.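

Within the data shown here, compound 1 and compound 3 both give only a limit, so no step between them can be read. The compounds shown leave open how strongly each inhibits and whether ((tert-butoxycarbonyl)amino)methyl in place of tert-butoxy changes that.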